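From 4-fluorophenoxy to methoxy on the shared core

This account rests on a few compounds, and the source may have more. Where it says the series, first, only, none or still open, it means among the compounds named here.

In a physicochemical assay for solubility, using the shake flask method, in simulated intestinal fluid, measured as kinetic solubility, with a stated time of 2 h, at 25 degrees C, at pH 6.5 (a lower number here means a less soluble compound, a higher number a more soluble compound), compound 3 `Cc1noc(-c2nc(C)c3c(c2N)C(=O)N(Cc2ccc(Oc4ccc(F)cc4)cc2)C3=O)n1` stands at 23800 nM as the lower of the two true numbers. Compound 2 `Cc1nc(C(=O)NC#N)c(N)c2c1C(=O)N(Cc1ccccc1)C2=O` at 185000 nM lies beyond the scatter above it. Compound 1 `Cc1nc(C#N)c(N)c2c1C(=O)N(Cc1ccccc1)C2=O` gives < 5000 nM as a limit and not a number. Compound 4 `COc1ccc(CN2C(=O)c3c(C)nc(-c4nc(C)no4)c(N)c3C2=O)cc1` carries methyl in place of 4-fluorophenyl on an oxygen on an aromatic ring. Within the data shown here, the only measured step of an at least 37-fold higher number from compound 1 to compound 2 (1.56 log units; beyond the scatter) is large, but it is a different change, cyanocarbamoyl in place of cyano on an aromatic carbon, so it sets no size for this one. The expected step of a 1.2-fold lower number from compound 3 to compound 4 (0.08 log units; within the scatter) therefore stays within the scatter of this assay with no firm direction. For compound 4 the estimated value is 20000 nM with an expected range of 5000 nM to 80000 nM around it.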

Compound 4, solubility: < 5000 nM
Compound 4: no number, only a limit (the forecaster's own chance of this, stated with the estimate: 15%); middle value at least 4.0-fold (0.60 log units) from the limit.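

In this assay, methyl in place of 4-fluorophenyl on an oxygen on an aromatic ring gives the first step shown at this position, and it lies beyond the scatter: an at least 4.7-fold lower number from compound 3 to compound 4 (0.67 log units; beyond the scatter). The 4-fluorophenoxy and methoxy compounds therefore do not read alike here. The step is only a bound, as the value of compound 4 is a limit and not a number: the limit of < 5000 nM in this assay, at which 2 of the 4 values shown sit.

From the compounds shown here alone, how far the true number of compound 4 lies from that limit stays open. So does how a longer chain or an aminoethyl group on that oxygen would read in this assay.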